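The source may hold more compounds than are shown below. What is called first, only, known or untested is meant among the compounds shown, and "the series" means these compounds.

In a functional assay on HeLa cells (Homo sapiens) for antiproliferative activity, read by WST assay, with a stated time of 72 h (a higher number here means a weaker inhibitor, a lower number a stronger inhibitor), compound 1 (`COC(=O)/C=C/c1ccc(NCc2ccccc2O)cc1`) gives 7170 nM and compound 2 (`COC(=O)/C=C/c1ccc(NCc2cc(Cl)ccc2O)cc1`) gives 8560 nM, so chloro in place of hydrogen on an aromatic carbon shifts nothing beyond the scatter: a 1.2-fold higher number from compound 1 to compound 2 (0.08 log units; within the scatter). Compound 3 (`COC(=O)/C=C/c1ccc(NCc2cccc(O)c2O)cc1`) stands at 68200 nM, the highest of the three numbers and so the weakest inhibitor of the set. The added hydroxy comes with a 9.5-fold higher number from compound 1 to compound 3 (0.98 log units; beyond the scatter).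

Compound 4 (`COC(=O)/C=C/c1ccc(NCc2cccc(OC)c2O)cc1`) differs from compound 3 in one place: methyl in place of hydrogen on an oxygen on an aromatic ring, or hydroxy to methoxy. For the measured compounds named here, no measured step makes this exact change. The closest evidence is the rise on adding that hydroxy to compound 1 (7170 nM), and methylation could undo part of it. A lower number in this assay is therefore expected, though not a full return, with an estimated step of a 3.1-fold lower number from compound 3 to compound 4 (0.49 log units; beyond the scatter). For compound 4 the estimate is 22000 nM, with an expected range of 7000 nM to 70000 nM.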

Compound 4, half-maximal inhibitory concentration: 3040 nM
Beside the measured number, compound 4's estimate is 7.2-fold (0.86 log units) above it; the measured number lies below the stated range.
By their numbers in this assay, from the lowest: compound 4; then compounds 1 and 2 (each within the scatter of the next); then compound 3.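

Capping the hydroxy with a methyl does more than recover what that hydroxy cost: in this assay there is a 22-fold lower number from compound 3 to compound 4 (1.35 log units; beyond the scatter), a large step from one added carbon. Measured against the unsubstituted compound, the same aromatic carbon gives opposite results, with a 9.5-fold higher number from compound 1 to compound 3 (0.98 log units; beyond the scatter) for hydroxy but a 2.4-fold lower number from compound 1 to compound 4 (0.37 log units; beyond the scatter) for methoxy, so this place accepts a substituent, and the outcome depends on whether its oxygen carries a hydrogen or a methyl. Nothing measured here explains why this single methyl has so large an effect.

The compounds shown leave open whether the lower number is particular to methoxy or extends to a longer chain on that oxygen, such as ethoxy, or to an amine on the same carbon. They also leave open what part the hydroxy shared by all four compounds plays.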